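The source may hold more compounds than are shown below. What is called first, only, known or untested is meant among the compounds shown, and "the series" means these compounds.

Measured compounds in a functional assay on the whole organism with Rattus norvegicus as the target, at a dose of 100 mg/kg; on this read-out lower numbers stand for less inhibition and higher numbers for more inhibition at the one dose given (going by the name of the read-out):
compound 1 `C/N=C(\S)NCCCCCn1nc(-c2ccccc2)ccc1=O` gives 68.9%
compound 2 `C/N=C(/NC#N)NCCCCCn1nc(-c2ccccc2)ccc1=O` gives 47.6%
compound 3 `N#CNC(=N)NCCCCn1nc(-c2ccccc2)ccc1=O` gives 61.2%

Compound 3 stands second highest of the three numbers in this assay. Its nearest neighbour is compound 1, and that gap is within the scatter, a number 7.7 percentage points lower from compound 1 to compound 3 (within the scatter), so the two cannot be ordered. Its furthest is compound 2, and that gap is beyond the scatter, a number 13.6 percentage points higher from compound 2 to compound 3 (beyond the scatter).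

Compound 4 `CC(C)C/N=C(\S)NCCCCn1nc(-c2ccccc2)ccc1=O` is not yet measured. It differs from compound 3 as follows: a group of 7 heavy atoms (5 carbon, 1 nitrogen, 1 sulfur; no ring) in place of a group of 5 heavy atoms (2 carbon, 3 nitrogen; no ring), on an amine nitrogen. The chain length is the same in both, so the change sits only in the terminal group.

Within the data shown here, the step that bears most directly on this is the one from compound 1 to compound 2, where the same kind of exchange ran the other way, a thiourea-type group replaced by a cyanoguanidine-type group on an amine nitrogen, and the read-out fell, a number 21.3 percentage points lower from compound 1 to compound 2 (beyond the scatter). Read in reverse, a cyanoguanidine-to-thiourea exchange should lift the number by a modest amount. Among the measured compounds shown here, the change in compound 4 also brings a larger alkyl group on the imine nitrogen than any measured compound carries, and no measured step covers that part, so the range stays wide.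

For compound 4 the expected step in this assay is a number 10.8 percentage points higher from compound 3 to compound 4 (beyond the scatter), and compound 4 is estimated at 72%, with a likely range from 56% to 88%.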

Compound 4, a percentage reported as inhibition, in the whole organism at one dose (the size of the read-out at that dose, not a potency): 35.8%
Compound 4: the middle estimate sits 36.2 percentage points above what was measured; measured number below the stated range.
By their numbers in this assay, from the lowest: compound 4; then compound 2; then compounds 3 and 1 (each within the scatter of the next).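

In this assay the exchange on an amine nitrogen does not raise the number: bringing in the group of 7 heavy atoms (5 carbon, 1 nitrogen, 1 sulfur) gives (a number 25.4 percentage points lower from compound 3 to compound 4 (beyond the scatter)), so a sulfur-bearing end group gives no gain on its own in this series. The sulfur-bearing compounds also sit far apart, with the change on the saturated chain carbon giving (a number 33.1 percentage points lower from compound 1 to compound 4 (beyond the scatter)), which shows that the rest of the group around the sulfur matters at least as much as the sulfur itself. The order of the two end group types also reverses relative to the earlier pair, as the change on the same saturated chain carbon gives (a number 11.8 percentage points lower from compound 2 to compound 4 (beyond the scatter)), so the earlier step does not transfer to a group with a larger alkyl substituent and a different chain length.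

Chain length and alkyl size change together in these comparisons, and an ethyl group on the same nitrogen, at the chain length of compound 4, would help separate the two. The measurements at hand offer no explanation for the fall in the number.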